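The compounds below may be only part of what the source reports. "The series", "measured", "known", "first", "only" and "open" are said of these compounds alone.

Compounds 1, 2 and 3 share one core and differ only in the group on the carbonyl carbon. Compound 1 `O=C(c1ccn(-c2ccc3c(c2)B(O)OC3)c1)c1ccc(Cl)cc1Cl` carries a 2,4-dichlorophenyl, compound 2 `Cc1ccccc1C(=O)c1ccn(-c2ccc3c(c2)B(O)OC3)c1` a 2-methylphenyl, and compound 3 `O=C(c1ccn(-c2ccc3c(c2)B(O)OC3)c1)c1cccs1` a thiophen-2-yl. In an ADME assay on L929 cells (Mus musculus) for cytotoxicity, read by resazurin assay, with a stated time of 72 h (a lower number here means a stronger inhibitor, a higher number a weaker inhibitor), compound 1 gives > 10 ug/mL, a limit of the assay rather than a number. In this assay compound 2 gives > 10 ug/mL, again a limit. In this assay compound 3 gives > 10 ug/mL, also a limit. Compound 3 thus stands at the limit of > 10 ug/mL in this assay, at which 3 of the 3 values shown sit. The steps a step that the two limits leave unreadable from compound 1 to compound 2, a step that the two limits leave unreadable from compound 1 to compound 3 and a step that the two limits leave unreadable from compound 2 to compound 3 carry no readable size. Compound 4 `Cc1ccc(C(=O)c2ccn(-c3ccc4c(c3)B(O)OC4)c2)s1` differs from compound 3 by methyl in place of hydrogen on an aromatic carbon. With every measured step unreadable, no direction beyond the scatter is expected; the expected step that the limit leaves unreadable from compound 3 to compound 4 is set near zero. Compound 4 is estimated at 15 ug/mL, between 7 ug/mL and 40 ug/mL.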

Compound 4, half-maximal inhibitory concentration: > 10 ug/mL
Compound 4 ended at the assay's limit (the forecaster's own chance of this, stated with the estimate: 80%); the middle value lies beyond the limit too.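

The steps from compound 3, compound 2 and compound 1 to compound 4 cannot be read, since each pair ends at a limit of the assay: the limit of > 10 ug/mL in this assay, at which 4 of the 4 values shown sit.

Where the cytotoxicity of compounds 1 to 4 actually lies in this assay, and whether the groups on the carbonyl carbon differ at all, stays open.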